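Returning a sulfur-linked group to the core

The source may hold more compounds than are shown below. What is called first, only, known or untested is meant among the compounds shown, and "the series" means these compounds.

Of the compounds shown here, three sharing one core have been measured in a functional assay on DU-145 cells (Homo sapiens) for inhibition, read by trypan blue exclusion, with a stated time of 72 h; on this read-out lower numbers stand for stronger inhibition and higher numbers for weaker inhibition. Compound 1 `Cn1c(=O)c(S(=O)(=O)c2ccc(F)cc2[N+](=O)[O-])cc2cnc(Nc3ccc4[nH]ccc4c3)nc21` gives 1500 nM. Compound 2 `Cn1c(=O)c(S(=O)(=O)c2ccc(O)cc2)cc2cnc(Nc3ccc4[nH]ccc4c3)nc21` gives 250 nM, and the step of a 6.0-fold lower number from compound 1 to compound 2 (0.78 log units; beyond the scatter) came with a 4-hydroxyphenyl in place of 4-fluoro-2-nitrophenyl on a sulfonyl sulfur. Compound 3 `Cn1c(=O)c(C(=O)Nc2ccc(F)cc2F)cc2cnc(Nc3ccc4[nH]ccc4c3)nc21` gives 5000 nM, the highest of the three numbers; the step of a 20-fold higher number from compound 2 to compound 3 (1.30 log units; beyond the scatter) came with (2,4-difluorophenyl)carbamoyl in place of (4-hydroxyphenyl)sulfonyl on an aromatic carbon.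

Compound 4 `Cn1c(=O)c(S(=O)(=O)Nc2ccc(F)cc2)cc2cnc(Nc3ccc4[nH]ccc4c3)nc21` is not yet measured. It differs from compound 3 by (4-fluorophenyl)sulfamoyl in place of (2,4-difluorophenyl)carbamoyl on an aromatic carbon. The step from compound 2 to compound 3 bears on this change most directly, since it removed a sulfonyl-linked aryl group and left a carbamoyl in its place, and it was large. The step from compound 1 to compound 2 shows that the aryl group carried by the sulfur also matters, at a modest size. Among the measured compounds shown here, no measured compound carries a sulfamoyl group, so the size is uncertain, but a lower number than compound 3 is expected in this assay, with the estimated step being a 6.3-fold lower number from compound 3 to compound 4 (0.80 log units; beyond the scatter). Compound 4 is therefore estimated at 800 nM, within a range from 200 nM to 3000 nM.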

Compound 4, half-maximal inhibitory concentration: 5000 nM
Estimate against measurement, compound 4: 6.3-fold (0.80 log units) below; measured number outside the range, above it.
By their numbers in this assay, from the lowest: compound 2; then compound 1; then compounds 3 and 4 (each within the scatter of the next).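

In this assay, putting (4-fluorophenyl)sulfamoyl in place of (2,4-difluorophenyl)carbamoyl on this aromatic carbon gave no change at the digits printed from compound 3 to compound 4 (within the scatter), so a sulfonyl on this carbon does not by itself bring the number down to that of compound 2. With the sulfonyl kept, (4-fluorophenyl)amino on the sulfur gave a 20-fold higher number from compound 2 to compound 4 (1.30 log units; beyond the scatter) and a 3.3-fold higher number from compound 1 to compound 4 (0.52 log units; beyond the scatter), so among the three sulfonyl compounds, what the sulfur carries separates the numbers, and both compounds with an aryl group directly on the sulfur stand lower than compound 4. The data shown offer no measurement that explains these steps.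

Each of these steps changes the link to the ring and the ring's substituents together, so the compounds shown do not separate the nitrogen in the link from the hydroxyl or the fluorines on the ring. A (4-hydroxyphenyl)amino group on the sulfur would part these two changes, while a simple amine or a carboxylic acid on this aromatic carbon would test whether an aryl group is needed here at all.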